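The source may report more compounds than this note shows. Statements on the series, on what has been measured and on what is new or still open speak of the compounds shown alone.

Working notes on the dichlorophenyl dihydropyridine series, all read in a functional assay (aorta) with Rattus norvegicus as the target; on this read-out higher numbers stand for weaker inhibition and lower numbers for stronger inhibition.

Compound 1 `CCO/C(O)=C1\C(COCC(O)CO)=NC(C)=C(C(=O)OC)C1c1cccc(Cl)c1Cl` gives 15.9 nM in this assay, the second highest of the three numbers in hand. Compound 2 `CCO/C(O)=C1\C(COCC(C)(C)O)=NC(C)=C(C(=O)OC)C1c1cccc(Cl)c1Cl` gives 6.31 nM, and compound 3 `CCO/C(O)=C1\C(COCC(C)(O)CSc2ncccn2)=NC(C)=C(C(=O)OC)C1c1cccc(Cl)c1Cl` gives 25.1 nM. The step of a 2.5-fold lower number from compound 1 to compound 2 (0.40 log units; beyond the scatter) shows that trimming the chain end to 1-hydroxy-1-methylethyl helps modestly; the step of a 1.6-fold higher number from compound 1 to compound 3 (0.20 log units; within the scatter) shows that a larger heteroaryl-bearing end returns to roughly the level of compound 1, and the step of a 4.0-fold higher number from compound 2 to compound 3 (0.60 log units; beyond the scatter) shows that the added (pyrimidin-2-yl)sulfanyl costs a modest amount against compound 2.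

Compound 4 `CCO/C(O)=C1\C(COCC(C)(O)Cn2cncn2)=NC(C)=C(C(=O)OC)C1c1cccc(Cl)c1Cl` differs from compound 1 by 1-((1H-1,2,4-triazol-1-yl)methyl)-1-hydroxyethyl in place of 1,2-dihydroxyethyl on a saturated chain carbon bound to an oxygen on a saturated carbon. Among the measured compounds shown here, the closest precedent is compound 3, which also carries a five-membered or six-membered heteroaryl on the hydroxylated chain end, so no step beyond the scatter is expected from compound 1. The estimate for compound 4 is 18 nM (range 7 nM to 45 nM), a step of a 1.1-fold higher number from compound 1 to compound 4 (0.05 log units; within the scatter) that is expected to stay within the scatter.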

Compound 4, half-maximal inhibitory concentration: 20 nM
Estimate against measurement, compound 4: 1.1-fold (0.05 log units) below; the measured number falls inside the stated range.
By their numbers in this assay, from the lowest: compound 2; then compounds 1, 4 and 3 (each within the scatter of the next).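

In this assay, the step of a 1.3-fold higher number from compound 1 to compound 4 (0.10 log units; within the scatter) shows that this saturated chain carbon bound to an oxygen on a saturated carbon accepts 1-((1H-1,2,4-triazol-1-yl)methyl)-1-hydroxyethyl, a five-membered aromatic ring end, in place of 1,2-dihydroxyethyl. Exchanging (pyrimidin-2-yl)sulfanyl for 1H-1,2,4-triazol-1-yl gives a 1.3-fold lower number from compound 3 to compound 4 (0.10 log units; within the scatter), while setting 1H-1,2,4-triazol-1-yl in place of hydrogen gives a 3.2-fold higher number from compound 2 to compound 4 (0.50 log units; beyond the scatter), so the modest loss seen with the pyrimidine end recurs with a second, different group. Nothing at hand speaks to the origin of these steps.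

The compounds shown leave open whether any group on this chain carbon gives that loss or only the two heteroaryl-bearing ones. A primary amine, a carboxylic acid or a plain phenyl at this place would separate those readings.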